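From Compound 3 to Its Ethoxy Counterpart, Compound 4

This account rests on a few compounds, and the source may have more. Where it says the series, first, only, none or still open, it means among the compounds named here.

Measured in a functional assay on PANC-1 cells (Homo sapiens) for antiproliferative activity, read by fluorescence and resazurin assay, with a stated time of 48 h; on this read-out higher numbers stand for weaker inhibition and lower numbers for stronger inhibition:
Compound 1 `CCOc1ccc2nc(Cl)c(/C=N/NC(=O)c3cc4cc([N+](=O)[O-])ccc4oc3=O)cc2c1`: 10500 nM
Compound 2 `CCOc1ccc2nc(Cl)c(/C=N/NC(=O)c3cc4ccccc4oc3=O)cc2c1`: 29900 nM
Compound 3 `O=C(N/N=C/c1cc2ccccc2nc1Cl)c1cc2cc(Br)ccc2oc1=O`: 5450 nM

Compound 3 and compound 1 lie within the scatter of each other, while compound 2 gives a number beyond the scatter above both. Compound 4 `CCOc1ccc2nc(Cl)c(/C=N/NC(=O)c3cc4cc(Br)ccc4oc3=O)cc2c1` differs from compound 3 by ethoxy in place of hydrogen on an aromatic carbon. Among the compounds with values here, no measured step shows this change itself. Within the data shown here, the only measured step, a 2.8-fold higher number from compound 1 to compound 2 (0.45 log units; beyond the scatter), is a change of another kind at another place, so it bears only indirectly. With ethoxy present, compound 1 gives 10500 nM, which suggests a small rise in the number at most. For compound 4 the expected value is 9000 nM, within an estimated range of 3500 nM to 22000 nM. This estimate means a 1.7-fold higher number from compound 3 to compound 4 (0.22 log units; within the scatter).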

Compound 4, half-maximal inhibitory concentration: 17000 nM
Beside the measured number, compound 4's estimate is 1.9-fold (0.28 log units) below it, and the stated range covers the measured number.
By their numbers in this assay, from the lowest: compounds 3, 1, 4 and 2 (each within the scatter of the next, the first and the last beyond it).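

In this assay, the ethoxy change on this aromatic carbon can now be read directly, with bromo held constant: a 3.1-fold higher number from compound 3 to compound 4 (0.49 log units; beyond the scatter). With ethoxy present, the two other single changes stay within the scatter: a 1.8-fold lower number from compound 2 to compound 4 (0.25 log units; within the scatter), and a 1.6-fold higher number from compound 1 to compound 4 (0.21 log units; within the scatter). No measured evidence here accounts for the ethoxy step.

This single pair leaves open whether ethoxy gives a similar step with nitro or hydrogen on the other ring. The compounds shown also leave open how an amine or a longer chain would compare at this carbon.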